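Benzyl substitution on the distal piperazine of compound 1

A few compounds are considered here, and "the series" means these few. Any claim that something is new, unique, unknown or untested is made for them only; others in the source may bear on it.

Compound 1 `CCN(CC)c1ccc2cc(C(=O)c3ccc(N4CCN(C(=O)CN5CCNCC5)CC4)cc3)oc2c1` carries a free amine nitrogen on its terminal ring. Among the measured compounds shown here, in a functional assay on HeLa cells (Homo sapiens) for cytotoxicity, read by MTT assay, with a stated time of 48 h (a higher number here means a weaker inhibitor, a lower number a stronger inhibitor), compound 1 gives 1350 nM, the lowest of the two numbers measured so far. Compound 2 `CCN(CC)c1ccc2cc(C(=O)c3ccc(N4CCN(C(=O)CN5CCN(Cc6ccc(/C=C/C(=O)OC)cc6)CC5)CC4)cc3)oc2c1`, which bears a substituted benzyl group on that same nitrogen, gives in this assay 3040 nM; the gap between compound 1 and compound 2 lies beyond the usual scatter, so the substituted analogue reads as weaker.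

Compound 3 `CCN(CC)c1ccc2cc(C(=O)c3ccc(N4CCN(C(=O)CN5CCN(Cc6ccc(F)c(F)c6)CC5)CC4)cc3)oc2c1` is the next case: 3,4-difluorobenzyl in place of hydrogen on an amine nitrogen in a ring. For the measured compounds named here, no measured pair describes this exact change, but compound 2 shows that adding a benzyl-type group on this nitrogen cost potency, and the difluorobenzyl group is smaller than the group in compound 2. A step from compound 1 to compound 3 of a 1.5-fold higher number from compound 1 to compound 3 (0.17 log units; within the scatter) toward a weaker number is expected in this assay, roughly at or within the edge of scatter. For compound 3 the expected value in this assay is 2000 nM, within 900 nM to 4500 nM.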

Compound 3, half-maximal inhibitory concentration: 6400 nM
Estimate against measurement, compound 3: 3.2-fold (0.51 log units) below, outside the stated range (above it).
By their numbers in this assay, from the lowest: compound 1; then compound 2; then compound 3.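

In this assay, 3,4-difluorobenzyl in place of hydrogen on this amine nitrogen gives a 4.7-fold higher number from compound 1 to compound 3 (0.68 log units; beyond the scatter), so a second substituted benzyl group also reads as weaker than the free amine, and no compound shown goes against this. The two benzyl-type groups also differ from each other, with a 2.1-fold higher number from compound 2 to compound 3 (0.32 log units; beyond the scatter), so the number at this position depends on what the aromatic ring carries and not only on the presence of a benzyl-type group. Nothing on hand gives a reason for either step.

From the compounds shown here alone, whether a plain benzyl, a methyl or an acetyl group on this nitrogen would stay closer to compound 1 remains open. Also open, going by these compounds, is how a single fluorine, or a carboxylic acid in place of the methoxycarbonyl group of compound 2, would read.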